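A few compounds are considered here, and "the series" means these few. Any claim that something is new, unique, unknown or untested is made for them only; others in the source may bear on it.

Compound 1 `CCOc1ccc2c(c1)NC(=O)Nc1cnc(C#N)c(n1)OCC/C=C\CO2`: > 10000 nM (a limit)
Compound 2 `N#Cc1ncc2nc1OCC/C=C\COc1ccccc1NC(=O)N2`: > 10000 nM (a limit)
Compound 3 `N#Cc1ncc2nc1OCC/C=C\COc1ccc(Cl)cc1NC(=O)N2`: > 10000 nM (a limit)

These three compounds were tested in a functional assay on NCI-H1299 cells (Homo sapiens), read by flow cytometry (on this read-out lower numbers stand for an effect already at smaller amounts and higher numbers for an effect only at larger amounts of compound), and none of them gave a number. Compound 3 stands at > 10000 nM, which is a limit of the assay and not a measured potency. It has no better-defined neighbour, as the series shows (the limit of > 10000 nM in this assay, at which 3 of the 3 values shown sit). Compound 4 `Cc1ccc2c(c1)NC(=O)Nc1cnc(C#N)c(n1)OCC/C=C\CO2` has not yet been measured. It differs from compound 3 in one place, with methyl in place of chloro on an aromatic carbon.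

Among the compounds with values here, three measured steps bear on this change, since each exchanges the group on an aromatic carbon while the shared core stays the same. They are a step that the two limits leave unreadable from compound 2 to compound 3, a step that the two limits leave unreadable from compound 1 to compound 2 and a step that the two limits leave unreadable from compound 1 to compound 3. None of them has a readable size, so they give no direction for this assay. Hydrogen, chloro and ethoxy all ended at the limit, so compound 4 is expected to sit there too. The expected change is a step that the limit leaves unreadable from compound 3 to compound 4, with no direction that the data can support. For compound 4 the estimated value is 15000 nM, with an expected range from 6000 nM to 40000 nM.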

Compound 4, half-maximal effective concentration: > 10000 nM
Compound 4 was reported as a limit; the forecaster's own chance of this, stated with the estimate: 85%; the middle value is on the limit's open side.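

In this assay compound 4 gives > 10000 nM as a limit of the assay and not a number. Within the data shown here, no step to compound 4 from compound 1, compound 2 or compound 3 can be read. The compounds shown leave open whether any of these groups on the aromatic carbon changes the result, or how they would rank: the limit of > 10000 nM in this assay, at which 4 of the 4 values shown sit.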